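A few compounds are considered here, and "the series" means these few. Any claim that something is new, unique, unknown or untested is made for them only; others in the source may bear on it.

Measured in a functional assay on HOP-62 cells (Homo sapiens) for inhibition, read by sulforhodamine B assay; a lower number here means a stronger inhibitor of growth, a higher number a weaker inhibitor of growth:
- compound 1 `Cc1ccc2[nH]c(-c3ccc(-c4ccc(-c5cccc(Cl)c5)cc4)cc3)nc2c1`: 2740 nM
- compound 2 `COc1ccc(-c2ccc(-c3ccc(-c4nc5cc(C)ccc5[nH]4)cc3)cc2)cc1OC`: 2120 nM
- compound 3 `FC(F)(F)c1ccc(-c2ccc(-c3ccc(-c4nc5ccccc5[nH]4)cc3)cc2)cc1`: 100000 nM

Compound 3, at 100000 nM, is the weakest of the three, and its gap to each of the other two lies beyond the scatter. Compound 4 `CN(C)c1ccc(-c2ccc(-c3ccc(-c4nc5ccccc5[nH]4)cc3)cc2)cc1` is the next to be read, with dimethylamino in place of trifluoromethyl on an aromatic carbon.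

Among the compounds with values here, only one measured step bears on this change, and only loosely. In a 1.3-fold lower number from compound 1 to compound 2 (0.11 log units; within the scatter), one substituted phenyl replaces another, and the result stays within the scatter. Within the data shown here, compound 3 and compound 4 also lack the methyl group carried by compound 1 and compound 2, so no measured step isolates the change at hand.

Compound 3 sits far from the other two values, so a move toward them is expected, though with wide uncertainty. The expected change is a 13-fold lower number from compound 3 to compound 4 (1.10 log units; beyond the scatter), a lower number and beyond the scatter. The estimate for compound 4 is 8000 nM, with an expected range of 1800 nM to 60000 nM.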

Compound 4, concentration for 50% growth inhibition: 100000 nM
For compound 4 the middle estimate is 13-fold (1.10 log units) below the measured one, and the stated range ends below it.
By their numbers in this assay, from the lowest: compounds 2 and 1 (each within the scatter of the next); then compounds 3 and 4 (each within the scatter of the next).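

In this assay, the change from 4-(trifluoromethyl)phenyl to 4-(dimethylamino)phenyl gives no change at the digits printed from compound 3 to compound 4 (within the scatter). Within the data shown here, this is the first reading of a substituent exchange on the core without the methyl group, and dimethylamino, which counts a hydrogen-bond acceptor where trifluoromethyl counts none, leaves the number where it stood. The earlier exchange of 3-chlorophenyl for 3,4-dimethoxyphenyl, a 1.3-fold lower number from compound 1 to compound 2 (0.11 log units; within the scatter), also stayed within the scatter, but on the methyl-bearing core. Nothing available here accounts for the unchanged number.

As far as these compounds go, whether another group at this place, such as a carboxylic acid, a primary amine or a hydroxyl group, would move the number on this core stays open. What the methyl group carried by compound 1 and compound 2 contributes also stays open, as no pair shown isolates it.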